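This account rests on a few compounds, and the source may have more. Where it says the series, first, only, none or still open, it means among the compounds named here.

Compound 2 `COc1cc(OC)c(C(=O)/C=C/c2ccccc2SC)c(OC)c1` is the stronger of the two measured compounds in a functional assay on PC-3 cells (Homo sapiens), read by fluorescence and BrdU incorporation, with a stated time of 48 h, tested at 25 uM; on this read-out higher numbers stand for a weaker effect at the one concentration tested and lower numbers for a stronger effect: it gives 0%, whereas compound 1 `COc1cc(O)c(C(=O)/C=C/c2ccc(F)cc2)c(OC)c1` gives 34%, a gap beyond the scatter. Compound 3 `COc1cccc(/C=C/C(=O)c2c(OC)cc(OC)cc2OC)c1` has not yet been measured. It differs from compound 2 in one place: 3-methoxyphenyl in place of 2-(methylsulfanyl)phenyl on a double-bonded chain carbon bound to a double-bonded chain carbon. Among the compounds with values here, no measured pair shows this kind of exchange, so the size of the step is open. A weakening beyond the scatter is nevertheless expected, estimated as a number 20 percentage points higher from compound 2 to compound 3 (beyond the scatter). Compound 3 is expected to give about 20%, within a range from 0% to 55%.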

Compound 3, a percentage reported as activity, at one concentration (the size of the read-out at that concentration, not a potency): 0.9%
For compound 3 the middle estimate is 19.1 percentage points above the measured one; the measured number falls inside the stated range.
By their numbers in this assay, from the lowest: compounds 2 and 3 (each within the scatter of the next); then compound 1.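

In this assay, placing 3-methoxyphenyl where 2-(methylsulfanyl)phenyl stood gives a number 0.9 percentage points higher from compound 2 to compound 3 (within the scatter) and so makes no readable difference. On this double-bonded chain carbon, then, the two groups can stand in for each other, at least in this single-concentration test, even though one carries sulfur and the other oxygen. No measurement shown offers an explanation for this result. Still open, from the compounds shown here alone, is whether an amine or a carboxylic acid on this ring would keep the read-out as low. Also open, going by these compounds, is whether this exchange would behave the same way on the core of compound 1.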